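A few compounds are considered here, and "the series" means these few. Any claim that something is new, unique, unknown or untested is made for them only; others in the source may bear on it.

Measured so far in an assay on isolated protein for inhibition of leukotriene B4 receptor 1 (Homo sapiens), tested at 10 uM; a lower number here means less inhibition, a higher number more inhibition at the concentration tested (going by the name of the read-out):
compound 1, `CCc1cc(C(C)=O)c(O)cc1OCCCCCCC#N`: 103%
compound 2, `COCc1cc(C(C)=O)c(O)cc1OCCCCCCC#N`: 47%
compound 3, `CC(=O)c1cc(CO)c(OCCCCCCC#N)cc1O`: 40%

Compound 1 stands highest of the three numbers in this assay. The nearest of the others is compound 2, a number 56 percentage points lower from compound 1 to compound 2 (beyond the scatter); the furthest is compound 3, a number 63 percentage points lower from compound 1 to compound 3 (beyond the scatter). Between the two lower compounds the difference is a number 7 percentage points lower from compound 2 to compound 3 (within the scatter).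

Compound 4, `CCc1cc(C(C)=O)c(O)cc1OCCCCCC(C)(C)C#N`, is not yet measured. It differs from compound 1 in one place: 1-cyano-1-methylethyl in place of cyanomethyl on a saturated chain carbon, five bonds along the chain from an oxygen on an aromatic ring. Every measured step in this set alters the group on a saturated chain carbon bound to an aromatic carbon, or the oxygen on that carbon; none touches the chain that carries the nitrile. The two large drops from compound 1 therefore say nothing direct about the change to compound 4, and the small step between compound 2 and compound 3 lies elsewhere as well. For the measured compounds named here, with no measured step bearing on this position, the step from compound 1 to compound 4 is expected to stay within the scatter, that is a number 8 percentage points lower from compound 1 to compound 4 (within the scatter). On that basis compound 4 is estimated at 95% in this assay. The expected range for compound 4 runs from 70% to 105%.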

Compound 4, a percentage reported as inhibition, at one concentration (the size of the read-out at that concentration, not a potency): 85%
Compound 4: the middle estimate sits 10 percentage points above what was measured, and the stated range covers the measured number.
By their numbers in this assay, from the lowest: compounds 3 and 2 (each within the scatter of the next); then compound 4; then compound 1.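

Replacing cyanomethyl with 1-cyano-1-methylethyl on a saturated chain carbon, five bonds along the chain from an oxygen on an aromatic ring, gives in this assay a number 18 percentage points lower from compound 1 to compound 4 (beyond the scatter). The nitrile-bearing chain is therefore not a silent place in the series, although this step is labelled modest, whereas the changes on the saturated chain carbon bound to an aromatic carbon are labelled large: a number 56 percentage points lower from compound 1 to compound 2 (beyond the scatter) and a number 63 percentage points lower from compound 1 to compound 3 (beyond the scatter). Nothing available here accounts for the fall in inhibition at this chain end.

One change at this place cannot show whether the loss follows the full 1-cyano-1-methylethyl group or would also appear with a single added methyl, as in 1-cyanoethyl, nor how a longer or shorter chain would read. Also open, on these data alone, is whether the nitrile itself matters, which an amide, a carboxylic acid or a tetrazole at the chain end would test, and whether the modest step seen on the core of compound 1 would be the same size on the methoxymethyl or hydroxymethyl compounds.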